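A Methyl Added to the Benzamide Ring of Compound 1

The source may hold more compounds than are shown below. What is called first, only, known or untested is meant among the compounds shown, and "the series" means these compounds.

Measured compounds:
compound 1, `O=C(NCN1CCC(c2cccc[n+]2[O-])CC1)c1ccccc1`, 532 nM
compound 2, `O=C(CN1CCC(c2ccccn2)CC1)Nc1c(Cl)cc(Cl)cc1Cl`, 145 nM
compound 3, `CC(C)Oc1cccc(NC(=O)CN2CCC(c3cccc[n+]3[O-])CC2)c1`, 555 nM

In a functional assay on HEK293 cells for agonist activity at D(4) dopamine receptor (Homo sapiens), read by FLIPR (on this read-out lower numbers stand for an effect already at smaller amounts and higher numbers for an effect only at larger amounts of compound), compound 1 gives 532 nM, the second highest of the three numbers. Compound 3 gives 555 nM, which lies within the scatter of compound 1, while compound 2 gives 145 nM, a lower number beyond the scatter. Compound 4 is `Cc1cccc(C(=O)NCN2CCC(c3cccc[n+]3[O-])CC2)c1`. It differs from compound 1 by methyl in place of hydrogen on an aromatic carbon, a change of one heavy atom on the shared core of compound 1. Within the data shown here, no measured pair shows this step, so its size is unknown. A step from compound 1 to compound 4 of a 1.2-fold lower number from compound 1 to compound 4 (0.07 log units; within the scatter) is expected, none beyond the scatter. Compound 4 is estimated at 450 nM, within 150 nM to 1400 nM.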

Compound 4, half-maximal effective concentration: 89 nM
For compound 4 the middle estimate is 5.1-fold (0.70 log units) above the measured one; measured number below the stated range.
By their numbers in this assay, from the lowest: compounds 4 and 2 (each within the scatter of the next); then compounds 1 and 3 (each within the scatter of the next).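

In this assay, among these compounds, going from phenyl to 3-methylphenyl gives a 6.0-fold lower number from compound 1 to compound 4 (0.78 log units; beyond the scatter), so a single added carbon on this aromatic carbon, meta to a large group, is enough to move the number beyond the scatter, which the earlier compounds could not show. This is the only step shown, so it rests on one pair. Nothing available here accounts for its size.

Still open, as far as these compounds go, is whether an ethyl group, a methoxy group or a chlorine atom at this place would give a similar step. Also open, from the compounds shown here alone, is whether methyl on another carbon of this ring would do the same.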